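Shifting the Nitro Group on the Aromatic Ring

A few compounds are considered here, and "the series" means these few. Any claim that something is new, unique, unknown or untested is made for them only; others in the source may bear on it.

Compound 2 `NC(=O)OC(CCN1CCN(c2ccccc2)CC1)c1cccc([N+](=O)[O-])c1` was tested in a functional assay on the whole organism for inhibition, with Mus musculus as the target, in the writhing test, with a stated time of 1 h, at a dose of 10 mg/kg by the intraperitoneal route (a higher number here means more inhibition at the dose given (going by the name of the read-out), a lower number less inhibition), and gave 100%. Its only comparator, compound 1 `NC(=O)OC(CCN1CCN(c2ccccc2)CC1)c1ccc(F)cc1`, gave 99% in this assay. Compound 2 therefore stands highest of the two numbers, but only by a number 1 percentage points higher from compound 1 to compound 2 (within the scatter), so the two compounds cannot be told apart on these data; both sit near the top of what the read-out can report.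

Compound 3 `NC(=O)OC(CCN1CCN(c2ccccc2)CC1)c1ccc([N+](=O)[O-])cc1` is the next compound to be measured. It differs from compound 2 by 4-nitrophenyl in place of 3-nitrophenyl on a saturated chain carbon bound to an oxygen next to a carbonyl group and a saturated chain carbon.

Among the measured compounds shown here, the one measured step that bears on this change, a number 1 percentage points higher from compound 1 to compound 2 (within the scatter), swapped one aromatic group for another at the same place and produced no step beyond the scatter. On that basis the expected step from compound 2 to compound 3 is a number 3 percentage points lower from compound 2 to compound 3 (within the scatter), with no direction beyond the scatter. Compound 3 is therefore estimated to give 97% in this assay, within a range of 85% to 100%.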

Compound 3, a percentage reported as inhibition, in the whole organism at one dose (the size of the read-out at that dose, not a potency): 100%
Compound 3: the middle estimate sits 3 percentage points below what was measured; measured number inside the range.
By their numbers in this assay, from the lowest: compounds 1, 2 and 3 (each within the scatter of the next).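

Moving the nitro group, with 4-nitrophenyl in place of 3-nitrophenyl, gives no change at the digits printed from compound 2 to compound 3 (within the scatter) in this assay and so adds a change of a new kind at this place: the same group in another ring position, with no visible effect at this dose. Nitro in place of fluoro on an aromatic carbon gives a number 1 percentage points higher from compound 1 to compound 3 (within the scatter) and so shows that this swap of ring group, too, cannot be told apart from the scatter in this test. Nothing measured here offers a reason for these flat results.

As far as these compounds go, all three compounds sit near the top of the read-out, so any difference between them at a lower dose stays unknown. From the compounds shown here alone, whether an amine or a carboxylic acid on the aromatic ring would keep this level of inhibition also remains open.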